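Methyl in place of hydrogen on two related cores

The source may report more compounds than this note shows. Statements on the series, on what has been measured and on what is new or still open speak of the compounds shown alone.

Three compounds of the series have numbers in a functional assay on A549 cells (Homo sapiens) for antiproliferative activity, read by sulforhodamine B assay, with a stated time of 48 h; on this read-out lower numbers stand for stronger inhibition and higher numbers for weaker inhibition. Compound 2 `COc1ccc(C(=O)/C=C\Nc2ccc(-c3nc4cc(OC)c(OC)c(OC)c4s3)cc2)cc1O` gives 23000 nM. Compound 1 `COc1ccc(C(=O)/C=C\Nc2ccc(-c3nc4cc(OC)c(OC)c(OC)c4s3)cc2C)cc1O` carries the change methyl in place of hydrogen on an aromatic carbon relative to compound 2; in this assay compound 1 gives 15400 nM; the step of a 1.5-fold lower number from compound 2 to compound 1 (0.17 log units; within the scatter) is the only measured instance of this change among the compounds shown. Compound 3 `COc1ccc2nc(-c3ccc(N/C=C\C(=O)c4cc(OC)c(OC)c([N+](=O)[O-])c4)cc3)sc2c1` gives 21600 nM; its two neighbours, compound 2 and compound 1, both lie within the scatter of it, so no order among the three can be read. The difference between the core of compound 3 and the core of compound 2 is not broken down here.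

Compound 4 `COc1ccc2nc(-c3ccc(N/C=C\C(=O)c4cc(OC)c(OC)c([N+](=O)[O-])c4)c(C)c3)sc2c1` is not yet measured. It differs from compound 3 by methyl in place of hydrogen on an aromatic carbon. Among the compounds with values here, this is the same kind of change as the one from compound 2 to compound 1, but not the same: in the earlier pair the new methyl sits meta to a large group, whereas in compound 4 it sits meta to a 6-methoxy-1,3-benzothiazol-2-yl group, and the rest of the core is not the same. Within the data shown here, on the single earlier example the step is expected to be small, about as seen in a 1.5-fold lower number from compound 2 to compound 1 (0.17 log units; within the scatter), so a 1.4-fold lower number from compound 3 to compound 4 (0.16 log units; within the scatter) is the estimated step. Compound 4 is therefore expected to give around 15000 nM in this assay, most likely between 6000 nM and 35000 nM, because compound 3 gives 21600 nM and the earlier methyl step stayed within the scatter.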

Compound 4, half-maximal inhibitory concentration: 22100 nM
Compound 4: middle estimate off by 1.5-fold (0.17 log units), on the low side; low and high end bracket the measured number.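

In this assay, methyl in place of hydrogen on the core of compound 3 gives a 1.0-fold higher number from compound 3 to compound 4 (0.01 log units; within the scatter), so on this core too the step does not leave the scatter. Set beside the earlier step, the second gives no sign that the outcome of this change depends on the core: the same change on two cores in this assay, a 1.5-fold lower number (0.17 log units; within the scatter) from compound 2 to compound 1 and a 1.0-fold higher number (0.01 log units; within the scatter) from compound 3 to compound 4, 1.5-fold (0.18 log units) apart, within the scatter of two such steps This shows only that the change stayed within the scatter on both of these cores; with just two pairs, it does not show that a methyl on this ring is without effect on other cores in the series, nor does it give a direction for the step, and it says nothing about the reason for either result.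

The compounds shown leave open whether any other group on this aromatic carbon, such as ethyl, a chlorine atom, an amine or a carboxylic acid, would give a step beyond the scatter. They also leave open which of the several differences between the core of compound 2 and the core of compound 3 matters in this assay, since no pair shown isolates any one of them, for example the nitro group alone.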